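The source may hold more compounds than are shown below. What is called first, only, known or untested is meant among the compounds shown, and "the series" means these compounds.

Measured compounds:
Compound 1 `CN(C)C(=O)c1ccncc1Nc1cc(-c2ccc3ccn(C)c3c2)c2nccnc2c1` — in an assay on lysate for inhibition of 6-phosphofructo-2-kinase/fructose-2,6-bisphosphatase 3 (Homo sapiens), with stated times of 0.5 min and 45 min (a higher number here means a weaker inhibitor, a lower number a stronger inhibitor), compound 1 gives > 100000 nM, which is a limit of the assay rather than a number.
Compound 2 `Cn1cc(NC(=O)c2ccncc2Nc2cc(-c3ccc4ccn(C)c4c3)c3nccnc3c2)cn1` — in this assay compound 2 gives 26500 nM.

Among the compounds with values here, compound 2 therefore holds the only actual number in this set; the other entry is a limit (the limit of > 100000 nM in this assay, at which 1 of the 2 values shown sits). Within the data shown here, the one measured step, an at least 3.7-fold lower number from compound 1 to compound 2 (0.57 log units; beyond the scatter), is the exchange of dimethylamino for (1-methyl-1H-pyrazol-4-yl)amino on the carbonyl carbon, and because compound 1 sits at the limit of > 100000 nM in this assay, at which 1 of the 2 values shown sits, its true size is only known as a lower bound.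

Compound 3 `Cn1cc(CNC(=O)c2ccncc2Nc2cc(-c3ccc4ccn(C)c4c3)c3nccnc3c2)cn1` differs from compound 2 in one place: (1-methyl-1H-pyrazol-4-yl)methyl in place of 1-methyl-1H-pyrazol-4-yl on an amide-type nitrogen. This keeps the same pyrazole but pushes it one carbon further from the amide nitrogen. Among the measured compounds shown here, no measured step spans this kind of insertion, so the step from compound 1 to compound 2 bears on it only in showing that this amide position tolerates a change without loss. The expected change is small, within the scatter, with a slight lean toward weaker inhibition, so the step is estimated as a 1.3-fold higher number from compound 2 to compound 3 (0.12 log units; within the scatter). Compound 3 is expected to give about 35000 nM in this assay, in the range 9000 nM to 100000 nM.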

Compound 3, half-maximal inhibitory concentration: 75900 nM
Estimate against measurement, compound 3: 2.2-fold (0.34 log units) below; measured number inside the range.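

In this assay the amide position turns out to be sensitive to more than the change of group: with the same pyrazole kept and only set one carbon further from the amide-type nitrogen, the result is a clear loss (a 2.9-fold higher number from compound 2 to compound 3 (0.46 log units; beyond the scatter)). The earlier pair could show only that adding the pyrazole helped, whereas this step shows that its distance from the amide nitrogen matters too, and that the directly attached 1-methyl-1H-pyrazol-4-yl is the better of these two arrangements. The comparison with the dimethylamino amide is much less informative (an at least 1.3-fold lower number from compound 1 to compound 3 (0.11 log units; that floor lies within the scatter)), and it gives only a floor because compound 1 gives a limit of the assay rather than a number: the limit of > 100000 nM in this assay, at which 1 of the 3 values shown sits.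

On these data alone, it remains open whether a longer chain, such as 2-(1-methyl-1H-pyrazol-4-yl)ethyl, on the same nitrogen would weaken inhibition further, or whether a phenyl or pyridine ring in place of the pyrazole would do better than either compound here. The data also give no reason for the loss, and even compound 2, with the lower number, gives only 26500 nM, so what would bring a much stronger inhibitor is also unanswered.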